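This account rests on a few compounds, and the source may have more. Where it says the series, first, only, none or still open, it means among the compounds named here.

Working notes on a two-member series sharing one core, with a third member pending. In a functional assay on MDA-MB-231 cells (Homo sapiens) for cytotoxicity, read by MTT assay, with a stated time of 38 h (a higher number here means a weaker inhibitor, a lower number a stronger inhibitor), compound 1 (`COc1cc(OC)c2c(=O)c(OCCCCN3CCCC3)c(-c3cc(OC)c(OC)c(OC)c3)oc2c1`) gives 10400 nM and compound 2 (`COc1cc(OC)c2c(=O)c(OCCCCN3CCCCC3)c(-c3cc(OC)c(OC)c(OC)c3)oc2c1`) gives 3030 nM, so compound 2 holds the lower of the two numbers.

Compound 3 (`COc1cc(OC)c2c(=O)c(OCCCCN3CCN(C)CC3)c(-c3cc(OC)c(OC)c(OC)c3)oc2c1`) is next, and its difference from compound 2 is 4-methylpiperazin-1-yl in place of piperidin-1-yl on a saturated chain carbon, four bonds along the chain from an oxygen on an aromatic ring. In words, 4-methylpiperazin-1-yl stands in place of piperidin-1-yl on a saturated chain carbon, four bonds along the chain from an oxygen on an aromatic ring.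

Within the data shown here, one measured step bears on this place: a 3.4-fold lower number from compound 1 to compound 2 (0.54 log units; beyond the scatter), modest but beyond the scatter, with piperidin-1-yl in place of pyrrolidin-1-yl. Among the measured compounds shown here, it exchanges a different pair of groups, and no measured compound yet carries 4-methylpiperazin-1-yl. From the compounds shown here alone, a step no larger than that one is therefore expected in this assay, leaning towards a higher number, though the direction remains open.

The estimated change is a 1.5-fold higher number from compound 2 to compound 3 (0.17 log units; within the scatter). For compound 3 the estimated value is 4500 nM, with an expected range from 1500 nM to 13000 nM.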

Compound 3, half-maximal inhibitory concentration: 3870 nM
For compound 3 the middle estimate is 1.2-fold (0.07 log units) above the measured one; low and high end bracket the measured number.
By their numbers in this assay, from the lowest: compounds 2 and 3 (each within the scatter of the next); then compound 1.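

At this place, on a saturated chain carbon, four bonds along the chain from an oxygen on an aromatic ring, this assay does not separate 4-methylpiperazin-1-yl from piperidin-1-yl: the step is a 1.3-fold higher number from compound 2 to compound 3 (0.11 log units; within the scatter) and so gives no sign that the second ring nitrogen and the added methyl matter in this read-out. Pyrrolidin-1-yl is now the outlier among the three groups, with the change to 4-methylpiperazin-1-yl being a 2.7-fold lower number from compound 1 to compound 3 (0.43 log units; beyond the scatter) and running the same way as the earlier change to piperidin-1-yl, a 3.4-fold lower number from compound 1 to compound 2 (0.54 log units; beyond the scatter) in that case, so both groups with a six-membered non-aromatic ring sit on the same side of compound 1, and neither goes against this within the three compounds. The data at hand offer no measured explanation for either the gap or the lack of one.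

Open, from the compounds shown here alone, is whether this holds for other amines at the chain end, such as morpholin-4-yl, an unsubstituted piperazin-1-yl or an open-chain dimethylamino group. Also open, going by these compounds, is whether a shorter or longer chain carrying the same rings would keep pyrrolidin-1-yl apart from the other two.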